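The source may report more compounds than this note shows. Statements on the series, on what has been measured and on what is new or still open speak of the compounds shown alone.

Three compounds of this series have numbers in a functional assay on ileum for antagonist activity at histamine H1 receptor (Cavia porcellus); on this read-out higher numbers stand for weaker binding and lower numbers for tighter binding. Compound 1 `N=C(NCCCc1c[nH]cn1)NCCSC(c1ccccc1)c1ccccn1` gives 100 nM in this assay. Compound 2 `COc1ccc(C(CC/N=C(\N)NCCCc2c[nH]cn2)c2ccccn2)cc1` gives 269 nM in this assay. Compound 3 `N=C(NCCCc1c[nH]cn1)NCCC(c1ccc(Cl)cc1)c1ccccn1` gives 77.6 nM in this assay, the lowest of the three numbers; its gap to compound 1 lies within the scatter, while its gap to compound 2 lies beyond it. Compound 4 `N=C(NCCCc1c[nH]cn1)NCCC(c1cc(F)cc(F)c1)c1ccccn1` has not yet been run in this assay. It differs from compound 3 in one place: 3,5-difluorophenyl in place of 4-chlorophenyl on a saturated chain carbon bound to an aromatic carbon and a saturated chain carbon. Among the compounds with values here, no measured pair isolates such a swap, so the expected step from compound 3 to compound 4 is a 1.5-fold higher number from compound 3 to compound 4 (0.19 log units; within the scatter), none beyond the scatter, if anything slightly toward a higher number. Compound 4 is thus estimated at 120 nM in this assay, with a range from 50 nM to 300 nM.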

Compound 4, dissociation constant: 275 nM
Compound 4: the middle estimate sits 2.3-fold (0.36 log units) below what was measured, within the range that was stated.
By their numbers in this assay, from the lowest: compounds 3 and 1 (each within the scatter of the next); then compounds 2 and 4 (each within the scatter of the next).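

At the saturated chain carbon bound to an aromatic carbon and a saturated chain carbon, the aryl group is not freely interchangeable in this assay: 3,5-difluorophenyl in place of 4-chlorophenyl gives a 3.5-fold higher number from compound 3 to compound 4 (0.55 log units; beyond the scatter) in this one pair. Within the data shown here, this is the only single-place comparison, and it shows that this position responds to a change of halogenated phenyl. Nothing measured here accounts for the step.

Still open, going by these compounds, is how 4-fluorophenyl or 3,5-dichlorophenyl would read at this carbon, which would separate a change of halogen from a change of its placement on the ring.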